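This account rests on a few compounds, and the source may have more. Where it says the series, first, only, none or still open, it means among the compounds named here.

Working notes on the series.

Compound 1 `Cc1ccc(NC(=O)c2ccc(C(F)(F)F)cc2)cc1-n1cc(-c2cnc3cccnn23)cn1` is the reference point here. In an ADME assay on HEK-293T cells (Homo sapiens) for cytotoxicity, read by CCK-8 assay, with a stated time of 24 h (a lower number here means that less compound is tolerated, a higher number that more compound is tolerated), compound 1 gives only a limit of the assay, > 80000 nM, and no number. Compound 2 `COc1ccc(C(=O)Nc2ccc(C)c(-n3cc(-c4cnc5ccnn5c4)cn3)c2)cc1` likewise sits at the limit, with > 80000 nM. Compound 3 `Cc1ccc(NC(=O)c2cccc(Cl)c2)cc1-n1cc(-c2cnc3cccnn23)cn1` also sits at the limit, giving > 80000 nM. Among the compounds with values here, the single measured step, a step that the two limits leave unreadable from compound 1 to compound 3, therefore has no readable size, and the only evidence on it is the limit of > 80000 nM in this assay, at which 3 of the 3 values shown sit.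

Compound 4 `CCc1ccc(C(=O)Nc2ccc(C)c(-n3cc(-c4cnc5cccnn45)cn3)c2)cc1` differs from compound 1 in one place: ethyl in place of trifluoromethyl on an aromatic carbon. The change sits on an aromatic carbon of a six-membered aromatic ring of carbon only, para to a large group; cut one bond further out, it reads 4-(trifluoromethyl)phenyl to 4-ethylphenyl.

Within the data shown here, the one measured step bears on this change only in that both of its ends are limits, so no step beyond the scatter is expected in this assay. Compound 4 is expected to give about 80000 nM, within 40000 nM to 160000 nM, most likely again as a limit. The step this estimate means, a number no higher from compound 1 to compound 4 (the limit leaves the size open), is expected to be none beyond the scatter.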

Compound 4, half-maximal cytotoxic concentration: > 80000 nM
Compound 4 gave a limit, no number; the forecaster's own chance of this, stated with the estimate: 85%; the middle value lies on the limit itself.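

In this assay compound 4 gives > 80000 nM, a limit and not a number, so its steps from compound 1 and compound 3 cannot be read: the limit of > 80000 nM in this assay, at which 4 of the 4 values shown sit.

The compounds shown leave open what concentration of any of them is half-maximally cytotoxic, and whether the changes on the carbonyl-bound ring alter it.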